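The compounds below may be only part of what the source reports. "The series", "measured", "known", "first", "only" and "open" are said of these compounds alone.

Measured so far:
Compound 1, `Cc1cccc2c1CCN2CCNC(=O)Nc1ccccc1Br`: 7.4
Compound 2, `O=C(Nc1ccccc1Br)N[C@@H]1CCN(c2cccc(F)c2)C1`: 7.8
Compound 3, `Cc1cccc(N2CC[C@@H](NC(=O)Nc3ccccc3Br)C2)c1`: 7.7

These three were tested in a functional assay for antagonist activity at transient receptor potential cation channel subfamily V member 1 (Rattus norvegicus), read by FLIPR; on this read-out higher numbers stand for higher potency (the scale is a negative logarithm) and lower numbers for lower potency. Compound 3 and compound 2 differ in one place only, (fluoro in place of methyl on an aromatic carbon), and this change brought a number 0.10 log units higher from compound 3 to compound 2 (within the scatter). Compound 1 and compound 3 are built from the same atoms joined differently; the difference between the two cores is not broken down here. Among the three, compound 1 gives the lowest number, and its value sits apart from that of compound 2 only.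

Compound 4, `O=C(NCCN1CCc2c(F)cccc21)Nc1ccccc1Br`, has not yet been measured in this assay. It differs from compound 1 by fluoro in place of methyl on an aromatic carbon. The surroundings are not identical: here the change sits on a ring that is part of a fused or bridged system of two rings, ortho to a fused ring and meta to a fused ring, whereas in compound 2 it sits meta to a large group, so it is the same kind of change rather than the same change. For compound 4 the step expected is a number 0.10 log units higher from compound 1 to compound 4 (within the scatter), because the same kind of change gave a number 0.10 log units higher from compound 3 to compound 2 (within the scatter). Compound 4 is therefore estimated at 7.5, probably between 7 and 8.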

Compound 4, negative logarithm of the antagonist equilibrium constant: 7.4
Compound 4: the middle estimate sits 0.10 log units above what was measured; low and high end bracket the measured number.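

In this assay, putting fluoro in place of methyl on an aromatic carbon of the core of compound 1 brought no change at the digits printed from compound 1 to compound 4 (within the scatter). The same kind of change therefore behaved alike on the two cores shown: the same change on two cores in this assay, a number 0.10 log units higher (within the scatter) from compound 3 to compound 2 and no change at the digits printed (within the scatter) from compound 1 to compound 4, 0.10 log units apart, within the scatter of two such steps This means that, for these two pairs, the swap can be carried from one core to the other without a shift that stands out from the ordinary spread of repeated measurements, but two small steps are too few to set a rule for the series, and they do not show that a step beyond the scatter would carry over in the same way.

The compounds shown leave open what other groups on this aromatic carbon would do, such as chloro, methoxy or nitrile. On these data alone, it also remains open whether a swap of the bromo group, for instance to a trifluoromethyl or a carboxylic acid, would carry from one core to the other as this one does.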